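A heteroaryl swap on the amide of a potent sulfone

This account rests on a few compounds, and the source may have more. Where it says the series, first, only, none or still open, it means among the compounds named here.

Three amides sharing one benzyl sulfone tail have been tested in an assay for inhibition of Nicotinamide phosphoribosyltransferase (Homo sapiens), read by mass spectrometry, with stated times of 15 min and 30 min; a lower number here means a stronger inhibitor, a higher number a weaker inhibitor. Compound 1 `O=C(NCc1ccc(S(=O)(=O)c2ccccc2)cc1)c1cc(-c2cccnc2)[nH]n1` gives 43 nM, compound 2 `Cn1c(C(=O)NCc2ccc(S(=O)(=O)c3ccccc3)cc2)cc2ccncc21` gives 410 nM, and compound 3 `O=C(NCc1ccc(S(=O)(=O)c2ccccc2)cc1)c1cc2ccncc2s1` gives 7 nM. Compound 3 therefore stands at the lowest number of the three, and both gaps, to compound 1 and to compound 2, lie beyond the usual scatter, so compound 3 is the strongest inhibitor among those measured.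

The next compound, compound 4 `O=C(NCc1ccc(S(=O)(=O)c2ccccc2)cc1)c1ccc2nncn2c1`, keeps everything of compound 3 except the group on the carbonyl carbon: a group of 9 heavy atoms (6 carbon, 3 nitrogen; one five-membered aromatic ring with 3 hetero atoms, one six-membered aromatic ring with 1 hetero atom) in place of a group of 9 heavy atoms (7 carbon, 1 nitrogen, 1 sulfur; one five-membered aromatic ring with 1 hetero atom, one six-membered aromatic ring with 1 hetero atom), on a carbonyl carbon. Whether this change helps or hurts cannot be read from the measured compounds, since none of them makes this exact exchange; the three measured groups on the carbonyl carbon already span a wide range in this assay. A modest weakening is expected, with a step of an 8.6-fold higher number from compound 3 to compound 4 (0.93 log units; beyond the scatter) that could well exceed the scatter. Compound 4 is estimated at 60 nM, within a range from 15 nM to 300 nM.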

Compound 4, half-maximal inhibitory concentration: 370 nM
For compound 4 the middle estimate is 6.2-fold (0.79 log units) below the measured one, and the stated range ends below it.
By their numbers in this assay, from the lowest: compound 3; then compound 1; then compounds 4 and 2 (each within the scatter of the next).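

In this assay the exchange on the carbonyl carbon produces a 53-fold higher number from compound 3 to compound 4 (1.72 log units; beyond the scatter) and counts as a large step, so this place does not accept every two-ring aromatic group of the same size. The entering group keeps the 9 heavy atoms and the pairing of a five-membered with a six-membered aromatic ring, yet it carries 3 nitrogen atoms and no sulfur, and it has 3 hydrogen-bond acceptors instead of 2, which shows that matching size and ring count is not enough to hold the strength of compound 3. Nothing measured here explains why this exchange weakens inhibition so much.

The compounds shown leave open which of the changed atoms accounts for the loss. They also leave open how an all-carbon naphthyl group on the carbonyl carbon would compare with compound 3.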